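Aziridine-nitrile ureas: butyl versus tert-butyl on the nitrogen

This account rests on a few compounds, and the source may have more. Where it says the series, first, only, none or still open, it means among the compounds named here.

The series is followed in a functional assay on MCF7 cells (Homo sapiens) for inhibition; on this read-out lower numbers stand for stronger inhibition and higher numbers for weaker inhibition. Compound 1 `CCOC(=O)c1ccc(NC(=O)N2CC2C#N)cc1` gives 3300 nM, and compound 3 `N#CC1CN1C(=O)Nc1cccnc1` gives 5400 nM; the two numbers sit within the usual scatter of each other, so no order between them is read. Compound 2 `CCCCNC(=O)N1CC1C#N` stands apart: its result is a limit of the assay and not a number, > 12000 nM. This is the point (the limit of > 12000 nM in this assay, at which 1 of the 3 values shown sits), and it is the weakest position on the numbers shown, with no value below it.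

Compound 4 `CC(C)(C)NC(=O)N1CC1C#N` is not yet measured. It differs from compound 2 in one place: tert-butyl in place of butyl on an amide-type nitrogen. Both are ureas in which the nitrogen carries an alkyl group of the same size, and only the branching changes.

Within the data shown here, no step between measured compounds exists here, so the expected size of the step from compound 2 to compound 4 rests on the position of compound 2 alone, which is at the limit. The step is expected to be none beyond the scatter, a step that the limit leaves unreadable from compound 2 to compound 4. Compound 4 is therefore estimated at 15000 nM, within 6000 nM to 40000 nM, and a further limit rather than a number is the more probable outcome.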

Compound 4, half-maximal inhibitory concentration: 120000 nM
Beside the measured number, compound 4's estimate is 8.0-fold (0.90 log units) below it, and the stated range ends below it.
By their numbers in this assay, from the lowest: compounds 1 and 3 (each within the scatter of the next); then compound 4.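

No step from compound 2 to compound 4 can be read, because the result for compound 2 is a limit and not a number: the limit of > 12000 nM in this assay, at which 1 of the 4 values shown sits.

With compound 4 at 120000 nM, the compounds shown leave open whether tert-butyl in place of butyl on an amide-type nitrogen changes inhibition in this assay at all, and by how much.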